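Working notes: amino for methyl on the aryl amine

A few compounds are considered here, and "the series" means these few. Any claim that something is new, unique, unknown or untested is made for them only; others in the source may bear on it.

Measured so far:
compound 1 `N[C@@H]1CCCN(c2cc(Nc3ccccc3Cl)n3nccc3n2)C1` — in an assay on isolated protein for inhibition of Dipeptidyl peptidase 9 (Homo sapiens) (on this read-out higher numbers stand for weaker inhibition and lower numbers for stronger inhibition), compound 1 gives > 100000 nM, which is a limit of the assay.
compound 2 `Cc1ccc(Nc2cc(N3CCC[C@@H](N)C3)nc3ccnn23)c(C)c1` — in this assay compound 2 gives > 100000 nM, which is a limit of the assay.

Compound 2 therefore stands at the limit of this assay, with no number of its own; the other value shown is also a limit. Going by the values given here, the only measured step, a step that the two limits leave unreadable from compound 1 to compound 2, cannot be read because the limit of > 100000 nM in this assay, at which 2 of the 2 values shown sit, leaves neither end as a number.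

Compound 3 `Cc1ccc(Nc2cc(N3CCC[C@@H](N)C3)nc3ccnn23)c(N)c1` differs from compound 2 by amino in place of methyl on an aromatic carbon. Among the compounds with values here, no measured step bears on this change: the one step recorded is unreadable and concerns a different group. Nothing in the data points to a change beyond the scatter in either direction in this assay, and the starting point is itself a limit. The step expected from compound 2 to compound 3 is thus a step that the limit leaves unreadable from compound 2 to compound 3, with a further limit the most likely outcome. Compound 3 is expected at 150000 nM, in the range 30000 nM to 1000000 nM.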

Compound 3, half-maximal inhibitory concentration: > 100000 nM
Compound 3: a limit, no number (the forecaster's own chance of this, stated with the estimate: 80%); the middle value does not contradict the limit.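

Going by these compounds alone, no step among compound 1, compound 2 and compound 3 can be read in this assay, because none of the three has a number of its own: the limit of > 100000 nM in this assay, at which 3 of the 3 values shown sit.

The compounds shown leave open whether 2-chlorophenyl, 2,4-dimethylphenyl and 2-amino-4-methylphenyl differ at all in this assay, and what inhibition, if any, the shared core can reach.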